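A few compounds are considered here, and "the series" means these few. Any claim that something is new, unique, unknown or untested is made for them only; others in the source may bear on it.

Measured compounds:
compound 1, `Cc1ccc(-c2nc3ncccc3o2)cc1`: 5%
compound 2, `Clc1ccc(-c2nc3ncccc3o2)cc1`: 24%
compound 3, `Cc1ccccc1-c1nc2cccnc2o1`: 3%

All three were tested in a functional assay on the whole organism for inhibition, with Rattus norvegicus as the target, at a dose of 30 mg/kg; on this read-out higher numbers stand for more inhibition at the one dose given (going by the name of the read-out) and lower numbers for less inhibition. In this assay compound 1 gives 5%, compound 2 gives 24%, and compound 3 gives 3%. Compounds 1 and 2 differ in one place, (chloro in place of methyl on an aromatic carbon), and that exchange gave a number 19 percentage points higher from compound 1 to compound 2 (beyond the scatter). Compound 1 and compound 3 have the same atoms joined differently; the difference between the two cores is not broken down here. Compound 4, `Clc1ccccc1-c1nc2cccnc2o1`, is not yet measured and differs from compound 3 by chloro in place of methyl on an aromatic carbon. The surroundings differ: in compound 1 the exchange sits para to a group of 9 heavy atoms, in compound 3 ortho to a group of 9 heavy atoms, so this is the same kind of change, not the same one. No ortho exchange of this kind has been measured. For the measured compounds named here, the expected step is a number 14 percentage points higher from compound 3 to compound 4 (beyond the scatter), set a little under the earlier one because the only measured step of this kind is a number 19 percentage points higher from compound 1 to compound 2 (beyond the scatter). Compound 4 is therefore estimated at 17%, from 2% to 35%.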

Compound 4, a percentage reported as inhibition, in the whole organism at one dose (the size of the read-out at that dose, not a potency): 50%
For compound 4 the middle estimate is 33 percentage points below the measured one, outside the stated range (above it).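

In this assay, chloro in place of methyl on an aromatic carbon gave a number 47 percentage points higher from compound 3 to compound 4 (beyond the scatter). The exchange raised the number on both cores, but the size of the step did not carry over from one to the other: the same change on two cores in this assay, a number 19 percentage points higher (beyond the scatter) from compound 1 to compound 2 and a number 47 percentage points higher (beyond the scatter) from compound 3 to compound 4, 28 percentage points apart, beyond the scatter of two such steps

For the compounds shown here, the direction therefore held in these two pairs, while the size of the step on one core gave no reliable measure of the step on the other; with only two pairs, and the exchange ortho to a group of 9 heavy atoms only in compound 3 and compound 4, the data cannot separate the place of the exchange from the rest of the core.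

The compounds shown leave open whether other groups at that place, such as fluoro, methoxy or an amine, would follow chloro. They also leave open how these numbers at a single dose relate to potency.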